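The source may report more compounds than this note shows. Statements on the series, on what has been measured and on what is new or still open speak of the compounds shown alone.

Compound 1 `COc1cc2c(Oc3ccc(NC(=O)c4nnn(-c5ccccc5C)c4C)cc3F)ccnc2cc1OCCCN1CCCCC1` and compound 2 `COc1cc2c(Oc3ccc(NC(=O)c4nnn(-c5ccc(F)cc5)c4C(F)(F)F)cc3F)ccnc2cc1OCCCN1CCCCC1` share most of their structure but differ in the aryl-bearing part of the amide; how the two cores differ is not broken down here. In a functional assay on U-87MG ATCC cells (Homo sapiens) for cytotoxicity, read by MTT assay, with a stated time of 72 h (on this read-out lower numbers stand for stronger inhibition and higher numbers for weaker inhibition), compound 1 gives 2370 nM, and compound 2 gives 1100 nM. Compound 3 `COc1cc2c(Oc3ccc(NC(=O)c4nnn(-c5ccccc5C)c4C)cc3F)ccnc2cc1OCCCN1CCC(C)CC1` carries the change methyl in place of hydrogen on a saturated ring carbon on the core of compound 1, and in this assay compound 3 gives 2160 nM, a step of a 1.1-fold lower number from compound 1 to compound 3 (0.04 log units; within the scatter). Compound 4 `COc1cc2c(Oc3ccc(NC(=O)c4nnn(-c5ccc(F)cc5)c4C(F)(F)F)cc3F)ccnc2cc1OCCCN1CCC(C)CC1` makes the same change, (methyl in place of hydrogen on a saturated ring carbon), on the core of compound 2. Because the earlier step of a 1.1-fold lower number from compound 1 to compound 3 (0.04 log units; within the scatter) was small, a step of about a 1.1-fold lower number from compound 2 to compound 4 (0.04 log units; within the scatter) is expected here too, so compound 4 is estimated to give about 1000 nM in this assay, roughly between 500 nM and 2000 nM.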

Compound 4, half-maximal inhibitory concentration: 800 nM
Compound 4: the middle estimate sits 1.3-fold (0.10 log units) above what was measured; the measured number falls inside the stated range.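

The change from piperidin-1-yl to 4-methylpiperidin-1-yl gives a 1.4-fold lower number from compound 2 to compound 4 (0.14 log units; within the scatter) in this assay. Set beside the earlier step, the change behaves alike on the two cores: the same change on two cores in this assay, a 1.1-fold lower number (0.04 log units; within the scatter) from compound 1 to compound 3 and a 1.4-fold lower number (0.14 log units; within the scatter) from compound 2 to compound 4, 1.3-fold (0.10 log units) apart, within the scatter of two such steps. This shows that the added methyl makes no readable difference on either core in this assay, but two small steps cannot show that it would do the same on other cores, or reveal a small real effect hidden in the scatter.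

The compounds shown leave open what a larger group on the same ring carbon, such as ethyl or hydroxyl, would do. They also leave open the effect of replacing the piperidine with a morpholine.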